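A few compounds are considered here, and "the series" means these few. Any claim that something is new, unique, unknown or untested is made for them only; others in the source may bear on it.

Of the compounds shown here, two built on a shared core have been measured in a physicochemical assay for lipophilicity; on this read-out higher numbers stand for higher lipophilicity and lower numbers for lower lipophilicity. Compound 1 `CCCCCCc1ccc(C#CC#Cc2cn([C@H]3C[C@H](O)[C@@H](CO)O3)c(=O)[nH]c2=O)cc1` gives 3.7, and compound 2 `Nc1cccc(C#CC#Cc2cn([C@H]3C[C@H](O)[C@@H](CO)O3)c(=O)[nH]c2=O)c1` gives 0.13. Compound 2 therefore holds the lower of the two numbers, and its gap to compound 1 lies well beyond the scatter of repeated measurements.

Compound 3 `Nc1ccc(C#CC#Cc2cn([C@H]3C[C@H](O)[C@@H](CO)O3)c(=O)[nH]c2=O)cc1` has not yet been measured. It differs from compound 2 in one place: 4-aminophenyl in place of 3-aminophenyl on a triple-bonded carbon. Put simply, 4-aminophenyl stands in place of 3-aminophenyl on a triple-bonded carbon, so the atoms are the same but joined differently. Within the data shown here, no measured pair shows what this kind of change does, so the natural starting point is compound 2 at 0.13. The expected result is a number 0.02 log units higher from compound 2 to compound 3 (within the scatter), a step within the scatter and with no clear direction. Compound 3 is estimated at 0.15, with an expected range of -0.25 to 0.55.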

Compound 3, partition coefficient: 0.13
For compound 3 the middle estimate is 0.02 log units above the measured one; the range from low to high includes it.
By their numbers in this assay, from the lowest: compounds 2 and 3 (each within the scatter of the next); then compound 1.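

In this assay, exchanging 3-aminophenyl for 4-aminophenyl on a triple-bonded carbon gives no change at the digits printed from compound 2 to compound 3 (within the scatter) and so, for this pair, the place of the amino group on the aromatic ring makes no difference that can be told from the scatter. Changing the group itself is another matter: amino in place of hexyl on an aromatic carbon gives a number 3.57 log units lower from compound 1 to compound 3 (beyond the scatter) as a large step. Among these three compounds, then, the large gap goes with the identity of the group and not with the shift of the amino group between the two ring places shown.

Going by these compounds, whether a butyl chain would fall part of the way along that step, or a carboxylic acid or dimethylamino group would sit with compounds 2 and 3, remains open. Nothing available here gives a reason for either step.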